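Clearance notes: the step from compound 2 to compound 4

A few compounds are considered here, and "the series" means these few. Any claim that something is new, unique, unknown or untested is made for them only; others in the source may bear on it.

In an ADME assay on microsomes from liver (Homo sapiens) for metabolic stability (a lower number here means slower removal, a higher number faster removal of the compound), compound 1 `CC(=O)N[C@@H]1CCC[C@H](C(=O)Nc2cc(-c3cnn4c3CCCC4)ccn2)C1` gives < 3 mL.min-1.g-1, which is a limit of the assay and not a number. Compound 2 `CC(=O)N[C@@H]1CCC[C@H](C(=O)Nc2cc(-c3cnn4c3CCCC4)c(F)cn2)C1` gives < 3 mL.min-1.g-1, also a limit. Compound 2 therefore stands only at the limit of < 3 mL.min-1.g-1 in this assay, at which 2 of the 3 values shown sit, with no number to start from. Going by the values given here, compound 3 `CC(=O)N[C@@H]1CCC[C@H](C(=O)Nc2cc(-c3cnn4c3NCCC4)c(Cl)cn2)C1` gives 6.2 mL.min-1.g-1, the only readable number so far.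

Compound 4 `CC(=O)N[C@@H]1CCC[C@H](C(=O)Nc2cc(-c3cnn4c3CC(C)(C)C4)c(F)cn2)C1` differs from compound 2 by a group of 10 heavy atoms (8 carbon, 2 nitrogen; one five-membered non-aromatic ring with 1 hetero atom, one five-membered aromatic ring with 2 hetero atoms) in place of a group of 9 heavy atoms (7 carbon, 2 nitrogen; one five-membered aromatic ring with 2 hetero atoms, one six-membered non-aromatic ring with 1 hetero atom), on an aromatic carbon. The change sits on an aromatic carbon opposite the ring nitrogen, and the fluoro group stays in place.

Among the compounds with values here, the one measured step, a step that the two limits leave unreadable from compound 1 to compound 2, concerns fluoro in place of hydrogen, and it offers no size to carry over. Within the data shown here, no measured step covers this exchange of groups, so the expectation is for no change beyond the scatter in this assay, with any movement more likely upward. The expected step is a number no lower from compound 2 to compound 4 (the limit leaves the size open). This expectation leans on compound 2, whose limit is < 3 mL.min-1.g-1. The upper side of the range leans on compound 3 at 6.2 mL.min-1.g-1. A report of compound 4 as a limit again would be no surprise. For compound 4 the estimated value is 3 mL.min-1.g-1, with an expected range from 1.5 mL.min-1.g-1 to 7 mL.min-1.g-1.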

Compound 4, intrinsic clearance in microsomes: 19 mL.min-1.g-1
Beside the measured number, compound 4's estimate is 6.3-fold (0.80 log units) below it, and the stated range ends below it.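

In this assay, the group with a five-membered non-aromatic ring and a five-membered aromatic ring in place of the group with a six-membered non-aromatic ring and a five-membered aromatic ring, on the aromatic carbon opposite the ring nitrogen and with the fluoro group kept, gives an at least 6.3-fold higher number from compound 2 to compound 4 (0.80 log units; beyond the scatter). Going by these compounds alone, this is the first readable step: the earlier step, fluoro in place of hydrogen, cannot be read between two limits, whereas this exchange shows that clearance in this assay is sensitive to the group at this position. Compound 2 is reported only as a limit of the assay and not as a number, so the printed size of the step is a floor: the limit of < 3 mL.min-1.g-1 in this assay, at which 2 of the 4 values shown sit.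

The compounds shown do not separate the change in size of the non-aromatic ring from the added carbon in the entering group, as the two change together. Going by these compounds, how a hydroxyl group or an amine on that non-aromatic ring would read in this assay remains open, as does whether the step holds with hydrogen in place of the fluoro group.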